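A Hydroxy Group Added to Compound 2

The source may hold more compounds than are shown below. What is called first, only, known or untested is meant among the compounds shown, and "the series" means these compounds.

Among the measured compounds shown here, only two compounds have been read so far in a functional assay on HeLa cells (Homo sapiens) for inhibition, read by trypan blue exclusion, with a stated time of 72 h; a lower number here means a stronger inhibitor of growth, a higher number a weaker inhibitor of growth. Compound 1 (`CCCn1c(-c2ccc(O)cc2)c(C)c2cc(O)ccc21`) gives 7900 nM. Compound 2 (`Cc1c(-c2ccc(O)cc2)[nH]c2ccccc12`) gives > 20000 nM, which is a limit of the assay and not a number. Compound 3 (`Cc1c(-c2ccc(O)cc2)[nH]c2ccc(O)cc12`) arises from compound 2 through one change: hydroxy in place of hydrogen on an aromatic carbon. For the measured compounds named here, no measured step isolates this change. Going by the values given here, the only guide is that a propyl chain is absent from compound 3 but present in compound 1, which shares the new hydroxy group and gives 7900 nM. A modest gain in growth inhibition is therefore expected, though a reading at the limit remains possible. The expected size of the move is an at least 1.4-fold lower number from compound 2 to compound 3 (0.15 log units; that floor lies within the scatter). For compound 3 the estimated value is 14000 nM, with an expected range of 6000 nM to 28000 nM.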

Compound 3, concentration for 50% growth inhibition: 16000 nM
Compound 3: the middle estimate sits 1.1-fold (0.06 log units) below what was measured; the range from low to high includes it.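

In this assay, hydroxy in place of hydrogen on the aromatic carbon gives an at least 1.2-fold lower number from compound 2 to compound 3 (0.09 log units; that floor lies within the scatter), so this change now has a step of its own, though only as a floor. From the compounds shown here alone, the true size of that step stays unknown because one end of it rests on a limit of the assay and not a number: the limit of > 20000 nM in this assay, at which 1 of the 3 values shown sits. With the hydroxy group held constant, hydrogen in place of propyl on the aromatic nitrogen gives a 2.0-fold higher number from compound 1 to compound 3 (0.31 log units; beyond the scatter), which isolates the propyl chain as a modest contributor to growth inhibition in this pair.

The compounds shown do not tell whether a methoxy group or an amine on this aromatic carbon would read differently from hydroxy. They also leave open how a butyl chain on the nitrogen would compare with propyl.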